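Trimming a Naphthyl Arm on a Nucleoside Scaffold

The source may report more compounds than this note shows. Statements on the series, on what has been measured and on what is new or still open speak of the compounds shown alone.

Compound 1 `Nc1ncnc2c1nc(NCc1ccc3ccccc3c1)n2[C@@H]1O[C@H](CO)[C@@H](O)[C@H]1O` carries a naphthalen-2-yl group and gives the lower of the two numbers seen so far. In an assay on COS-7 cells for inhibition of sodium/nucleoside cotransporter 2 (Homo sapiens), read by scintillation counting, in the presence of a further agent that is not named here (a lower number here means a stronger inhibitor, a higher number a weaker inhibitor), compound 1 gives 5300 nM, while compound 2 `Nc1ncnc2c1nc(NCc1cccc(-c3ccccc3)c1)n2[C@@H]1O[C@H](CO)[C@@H](O)[C@H]1O`, which bears a biphenyl group instead, gives 21000 nM, a gap beyond the scatter. Compound 3 `Nc1ncnc2c1nc(NCc1ccc(Cl)cc1)n2[C@@H]1O[C@H](CO)[C@@H](O)[C@H]1O` has not yet been measured; it differs from compound 1 by 4-chlorophenyl in place of naphthalen-2-yl on a saturated chain carbon bound to a nitrogen on an aromatic ring. Among the compounds with values here, no measured pair shows the effect of such a change, so the step is expected to be modest and to lean toward a weaker inhibitor, a 1.7-fold higher number from compound 1 to compound 3 (0.23 log units; within the scatter). For compound 3 the estimate is 9000 nM, within 3000 nM to 30000 nM.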

Compound 3, half-maximal inhibitory concentration: 11000 nM
Compound 3: middle estimate off by 1.2-fold (0.09 log units), on the low side; the range from low to high includes it.
By their numbers in this assay, from the lowest: compound 1; then compounds 3 and 2 (each within the scatter of the next).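

Within the data shown here, replacing naphthalen-2-yl with 4-chlorophenyl on this saturated chain carbon is the first single change read directly at this position, and in this assay it gives a 2.1-fold higher number from compound 1 to compound 3 (0.32 log units; beyond the scatter). Two things change at once here: one of the two aromatic rings leaves and a chlorine enters, yet the cost to inhibition is modest. Nothing on hand explains this step. The compounds shown do not separate the loss of the ring from the gain of the chlorine. A plain phenyl, a 4-methoxyphenyl or a pyridine ring could help to pull these two apart.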